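Hydroxy for Methoxy: Compound 4 Awaits Its Value

This account rests on a few compounds, and the source may have more. Where it says the series, first, only, none or still open, it means among the compounds named here.

Compound 1 `O=C(Nc1cccc(-n2cc(-c3ccncc3)c(-c3ccc(Cl)c(O)c3)n2)c1)Nc1cccc(C(F)(F)F)c1` — in a functional assay on Malme-3M cells (Homo sapiens) for inhibition, read by sulforhodamine B assay, with a stated time of 48 h (a higher number here means that more compound is tolerated, a lower number that less compound is tolerated), compound 1 gives > 32500 nM, which is a limit of the assay.
Compound 2 `COc1cc(-c2nn(-c3cccc(NC(=O)Nc4cccc(C(F)(F)F)c4)c3)cc2-c2ccncc2)ccc1Cl` — in this assay compound 2 gives 33900 nM.
Compound 3 `COc1cc(-c2nn(-c3cccc(NC(=O)Nc4ccc(Cl)c(C(F)(F)F)c4)c3)cc2-c2ccncc2)ccc1Cl` — in this assay compound 3 gives > 32500 nM, which is a limit of the assay.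

Compounds 1 and 2 share a core and differ only by hydrogen in place of methyl on an oxygen on an aromatic ring. The step that the limit leaves unreadable from compound 2 to compound 1 cannot be sized because of the limit of > 32500 nM in this assay, at which 2 of the 3 values shown sit. Compound 3 differs from compound 2 by chloro in place of hydrogen on an aromatic carbon, and the step that the limit leaves unreadable from compound 2 to compound 3 stays unreadable for the same reason, because of the limit of > 32500 nM in this assay, at which 2 of the 3 values shown sit. Of the three measured compounds, then, only compound 2 returns a number, and that number sits right at the edge of what the assay can report.

Compound 4 `O=C(Nc1cccc(-n2cc(-c3ccncc3)c(-c3ccc(Cl)c(O)c3)n2)c1)Nc1ccc(Cl)c(C(F)(F)F)c1` has not yet been measured. It differs from compound 3 by hydrogen in place of methyl on an oxygen on an aromatic ring, the same change as from compound 2 to compound 1, here made on the core of compound 3 rather than on that of compound 2; the two cores differ as described by chloro in place of hydrogen on an aromatic carbon. For this assay the step is expected to be a step that the limit leaves unreadable from compound 3 to compound 4, and this expectation rests on the earlier step that the limit leaves unreadable from compound 2 to compound 1, which left compound 1 at the limit, together with compound 3 already standing at the limit. Compound 4 is therefore expected to come out near 36000 nM, somewhere between 24000 nM and 70000 nM, and most likely to be reported as a limit once more.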

Compound 4, concentration lethal to 50% of the cells: 9580 nM
Estimate against measurement, compound 4: 3.8-fold (0.57 log units) above; measured number below the stated range.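

In this assay, the change from methoxy to hydroxy amounts to an at least 3.3-fold lower number from compound 3 to compound 4 (0.53 log units; beyond the scatter), and chloro in place of hydrogen on an aromatic carbon amounts to an at least 3.3-fold lower number from compound 1 to compound 4 (0.53 log units; beyond the scatter); each of these steps is beyond the scatter, and each is stated only as a minimum. From the compounds shown here alone, the matching step from compound 2 to compound 1 and the step from compound 2 to compound 3 cannot be read, so it remains unknown whether methoxy to hydroxy has the same size on both cores, because those comparisons end at a limit: the limit of > 32500 nM in this assay, at which 2 of the 4 values shown sit. The result therefore shows that the change can lower the number on one core, but one readable pair does not show that it carries over to another core, and it gives no reason for the lower number.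

The compounds shown leave open how an amine or a carboxylic acid in place of the hydroxy would read in this assay, and whether an ethoxy group would read like the methoxy or like the hydroxy. Also open are the exact numbers for compound 1 and compound 3, as each of these compounds is reported only as a limit.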